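This account rests on a few compounds, and the source may have more. Where it says the series, first, only, none or still open, it means among the compounds named here.

In a functional assay on PC-3 cells (Homo sapiens) for inhibition, read by MTT assay, with a stated time of 48 h (on this read-out higher numbers stand for weaker inhibition and lower numbers for stronger inhibition), the three measured compounds read as follows.
Compound 1 `CCn1c(/C=C2\SC(=O)N(CC(=O)N3CCCCC3)C2=O)nc2ccccc21` gives > 50000 nM, which is a limit of the assay and not a number.
Compound 2 `CCn1c(/C=C2\SC(=O)N(CC(=O)Nc3cc(C(C)(C)C)on3)C2=O)nc2ccccc21` gives > 50000 nM, again a limit.
Compound 3 `CCn1c(/C=C2\SC(=O)N(CC(=O)N3CCCC3)C2=O)nc2ccccc21` gives > 50000 nM, also a limit.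

Compound 3 thus stands at a limit, and the two other values shown are limits as well; (the limit of > 50000 nM in this assay, at which 3 of the 3 values shown sit). Compound 4 `CCn1c(/C=C2\SC(=O)N(CC(=O)N3CC(C)OC(C)C3)C2=O)nc2ccccc21` differs from compound 3 in one place: 2,6-dimethylmorpholin-4-yl in place of pyrrolidin-1-yl on a carbonyl carbon. The measured steps that alter the same carbonyl-bound group are a step that the two limits leave unreadable from compound 1 to compound 3, a step that the two limits leave unreadable from compound 1 to compound 2 and a step that the two limits leave unreadable from compound 2 to compound 3; all three sit at the limit, so none has a readable size or direction. For compound 4 no step beyond the scatter is expected, the estimated step being a step that the limit leaves unreadable from compound 3 to compound 4. Compound 4 is expected to give 80000 nM, in the range 30000 nM to 300000 nM, most probably reported once more as a limit.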

Compound 4, half-maximal inhibitory concentration: > 50000 nM
Compound 4 ended at the assay's limit; the forecaster's own chance of this, stated with the estimate: 90%; the middle value does not contradict the limit.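

Compound 4 sits at a limit, as do compound 1, compound 2 and compound 3, so no step to compound 4 can be read: the limit of > 50000 nM in this assay, at which 4 of the 4 values shown sit.

The compounds shown leave open whether any group on this carbonyl carbon gives a readable value in this assay.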